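This account rests on a few compounds, and the source may have more. Where it says the series, first, only, none or still open, it means among the compounds named here.

Of the compounds shown here, three that share one core have been measured in a functional assay on the whole organism with Mus musculus as the target; on this read-out lower numbers stand for smaller maximal responses and higher numbers for larger maximal responses. Compound 1 `CCOC(=O)Cn1c(=O)n(C2OC(CO)[C@@H](O)[C@H]2O)c2nc(N)nc(O)c21` gives 58% in this assay. Compound 2 `C=CCn1c(=O)n([C@@H]2O[C@H](CO)[C@H]3OC(=O)O[C@H]32)c2nc(N)nc(O)c21` gives 97% in this assay, and compound 3 `C=CCn1c(=S)n(C2OC(COC(C)=O)[C@H]3OC(C)(C)O[C@@H]23)c2nc(N)nc(O)c21` gives 20% in this assay. Compound 1 therefore stands second highest of the three numbers: compound 2 lies above it by a gap that goes beyond the usual scatter, and compound 3 lies below it by a gap that also goes beyond the scatter.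

Compound 4 `Nc1nc(O)c2c(n1)n(C1OC(CO)[C@@H](O)[C@H]1O)c(=O)n2CCN1CCCCC1` has not yet been measured. It differs from compound 1 in a single place: (piperidin-1-yl)methyl in place of ethoxycarbonyl on a saturated chain carbon bound to an aromatic nitrogen. The group that leaves has no ring, while the group that enters brings one six-membered non-aromatic ring with one hetero atom; cut one bond further out, the same difference reads (ethoxycarbonyl)methyl to 2-(piperidin-1-yl)ethyl. Among the compounds with values here, no pair of measured compounds shows what such an exchange does in this assay, so the step that is expected, a number 3 percentage points lower from compound 1 to compound 4 (within the scatter), is taken to stay within the scatter in either direction. On that basis compound 4 is estimated at 55% in this assay, with a range from 30% to 80%.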

Compound 4, largest response reached (reported as maximal response), in percent of the reference or control that the assay uses: 0%
Compound 4: the middle estimate sits 55 percentage points above what was measured; measured number outside the range, below it.
By their numbers in this assay, from the lowest: compound 4; then compound 3; then compound 1; then compound 2.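

In this assay, the step from the ester to the ring-bearing group is large: (piperidin-1-yl)methyl in place of ethoxycarbonyl gives a number 58 percentage points lower from compound 1 to compound 4 (beyond the scatter). Within the data shown here, this is the first comparison that changes one place only, and it shows that the group on this saturated chain carbon bound to an aromatic nitrogen can decide whether any response remains. Nothing at hand says why the response changes so much.

This single exchange cannot separate the loss of the ethoxycarbonyl from the arrival of the piperidine ring. A 2-(dimethylamino)ethyl group, which has an amine but no ring, or a carboxymethyl group, which has a carboxylic acid in place of the ester, would help show which part of the change goes with the step.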